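A few compounds are considered here, and "the series" means these few. Any claim that something is new, unique, unknown or untested is made for them only; others in the source may bear on it.

Going by the values given here, compound 1 `CCCCCCCCNc1nc(SCc2ccc(C(F)(F)F)cc2)nc2ccccc12` is the only member of this set with an actual number in a functional assay on MCF7 cells (Homo sapiens) for cytotoxicity, read by MTT assay, with a stated time of 72 h; on this read-out higher numbers stand for weaker inhibition and lower numbers for stronger inhibition: compound 1 gives 26100 nM. Compound 2 `FC(F)(F)c1ccc(CSc2nc(N3CCCCC3)c3ccccc3n2)cc1` in this assay reaches only > 50000 nM, which is a limit of the assay rather than a number. Compound 3 `FC(F)(F)c1ccc(CSc2nc(Nc3ccccc3Cl)c3ccccc3n2)cc1` likewise gives only > 50000 nM, again a limit. Compound 4 `CCOc1ccccc1Nc1nc(SCc2ccc(C(F)(F)F)cc2)nc2ccccc12` is the next change from compound 1: 2-ethoxyphenyl in place of octyl on a nitrogen on an aromatic ring. The measured steps that bear on it are an at least 1.9-fold higher number from compound 1 to compound 2 (0.28 log units; that floor lies within the scatter) and an at least 1.9-fold higher number from compound 1 to compound 3 (0.28 log units; that floor lies within the scatter), both of which end at the limit of > 50000 nM in this assay, at which 2 of the 3 values shown sit. A step in the same direction from compound 1 to compound 4 is therefore expected, most likely ending at the limit as well. Compound 4 is estimated at 55000 nM with a range of 20000 nM to 150000 nM. That estimate means an expected step of a 2.1-fold higher number from compound 1 to compound 4 (0.32 log units; beyond the scatter).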

Compound 4, half-maximal inhibitory concentration: > 50000 nM
Compound 4: a limit, no number (the forecaster's own chance of this, stated with the estimate: 60%); the middle value lies beyond the limit too.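

In this assay, 2-ethoxyphenyl in place of octyl on a nitrogen on an aromatic ring gives an at least 1.9-fold higher number from compound 1 to compound 4 (0.28 log units; that floor lies within the scatter), so a second aromatic group at this place, now carrying ethoxy in place of chloro, also yields no number. The result for compound 4 is a limit, not a number, and the steps among compound 2, compound 3 and compound 4 cannot be read. Octyl in compound 1 remains the only group here with a number, and the set stays largely at the limit: the limit of > 50000 nM in this assay, at which 3 of the 4 values shown sit.

Going by these compounds, how a decyl chain, or an amine on the octyl chain, would read at this place stays open. Also open, on these data alone, is whether any group on this nitrogen gives a clearly lower number than compound 1.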